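Fluorophenyl positional shift in the hydrazone series

The source may report more compounds than this note shows. Statements on the series, on what has been measured and on what is new or still open speak of the compounds shown alone.

Compound 2 `O=C(CSc1nnc(-c2ccncc2)n1-c1ccccc1)N/N=C/c1ccc(F)cc1` gives 9330 nM in a functional assay on HepG2 cells (Homo sapiens) for inhibition, read by MTT assay, with a stated time of 48 h; a lower number here means a stronger inhibitor, a higher number a weaker inhibitor; compound 1 `O=C(CSc1nnc(-c2ccncc2)n1-c1ccccc1)N/N=C/c1ccc(Br)cc1` gives 5990 nM, and the step of a 1.6-fold higher number from compound 1 to compound 2 (0.19 log units; within the scatter) is within the scatter, so compound 2 sits together with compound 1 among the two numbers measured. Compound 3 `O=C(CSc1nnc(-c2ccncc2)n1-c1ccccc1)N/N=C/c1cccc(F)c1` differs from compound 2 by 3-fluorophenyl in place of 4-fluorophenyl on a carbon with a double bond to nitrogen. Within the data shown here, no measured step moves the fluorine around the ring; the single step measured, fluoro for bromo, stayed within the scatter, so no change beyond the scatter is expected in this assay in either direction. Compound 3 is therefore estimated at 9000 nM with a range of 4000 nM to 20000 nM. That estimate means an expected step of a 1.0-fold lower number from compound 2 to compound 3 (0.02 log units; within the scatter).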

Compound 3, half-maximal inhibitory concentration: 24400 nM
Beside the measured number, compound 3's estimate is 2.7-fold (0.43 log units) below it; measured number outside the range, above it.
By their numbers in this assay, from the lowest: compounds 1 and 2 (each within the scatter of the next); then compound 3.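

The position of the fluorine on this ring counts in this assay: 3-fluorophenyl in place of 4-fluorophenyl gives a 2.6-fold higher number from compound 2 to compound 3 (0.42 log units; beyond the scatter), a change beyond the scatter, whereas fluoro for bromo stayed within it. With a 4.1-fold higher number from compound 1 to compound 3 (0.61 log units; beyond the scatter) as well, compound 3 stands apart from both other compounds, on the weaker side. Nothing at hand explains this shift.

From the compounds shown here alone, whether the shift belongs to fluoro alone or to any group placed this way remains open. 3-Bromophenyl and 3-aminophenyl on the same carbon would test this.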